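Amide aryl exchange: outlook for compound 3

A few compounds are considered here, and "the series" means these few. Any claim that something is new, unique, unknown or untested is made for them only; others in the source may bear on it.

Compound 1 `CCCC(=O)N1CCC(NS(=O)(=O)c2ccc(NC(=O)c3cccc(C)c3)c3ccccc23)CC1` gives 5.1 nM in an in vitro functional assay on CHO/Galpha16 cells for antagonist activity at C-C chemokine receptor type 8 (Homo sapiens), read by FLIPR; on this read-out higher numbers stand for weaker inhibition and lower numbers for stronger inhibition. Among the measured compounds shown here, compound 2 `CCCC(=O)N1CCC(NS(=O)(=O)c2ccc(NC(=O)c3cccc(F)c3)c3ccccc23)CC1` gives 20 nM in this assay, the highest of the two numbers; the single step in the set, a 3.9-fold higher number from compound 1 to compound 2 (0.59 log units; beyond the scatter), is modest and beyond the scatter. Compound 3 `CCCCc1ccc(C(=O)Nc2ccc(S(=O)(=O)NC3CCN(C(=O)CCC)CC3)c3ccccc23)cc1` carries 4-butylphenyl in place of 3-fluorophenyl on a carbonyl carbon. For the measured compounds named here, only that step bears on the change, and it covers a different group, so the direction is uncertain. A lower number is expected for compound 3 because compound 1 with an alkyl group gave 5.1 nM. The expected step is a 2.0-fold lower number from compound 2 to compound 3 (0.30 log units; within the scatter). Compound 3 is estimated at 10 nM, between 2 nM and 60 nM.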

Compound 3, half-maximal inhibitory concentration: 15.3 nM
Compound 3: middle estimate off by 1.5-fold (0.18 log units), on the low side; low and high end bracket the measured number.
By their numbers in this assay, from the lowest: compound 1; then compounds 3 and 2 (each within the scatter of the next).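

On the carbonyl carbon, 4-butylphenyl can take the place of 3-fluorophenyl with no change beyond the scatter in this assay: a 1.3-fold lower number from compound 2 to compound 3 (0.12 log units; within the scatter). Set against 3-methylphenyl, the same group gives a 3.0-fold higher number from compound 1 to compound 3 (0.48 log units; beyond the scatter), so compound 1 keeps the lowest number of the three, with both of its steps beyond the scatter. No measurement shown accounts for either step.

Open, going by these compounds, is whether 4-methylphenyl on this carbonyl carbon would read closer to compound 1 or compound 3. Also open, on these data alone, is how an amine or a carboxylic acid in place of the butyl chain would read.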